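Methyl for fluoro on a shared core: an expected step

This account rests on a few compounds, and the source may have more. Where it says the series, first, only, none or still open, it means among the compounds named here.

compound 1 `Oc1ccc(Nc2nc(-c3ccc(F)cc3)cs2)cc1`: 60 nM
compound 2 `Oc1ccc(Nc2nc(-c3ccc(Cl)c(Cl)c3)cs2)cc1`: 30 nM

Both compounds were tested in an assay on isolated protein for inhibition of Polyunsaturated fatty acid 5-lipoxygenase (Homo sapiens), read by HPLC, with stated times of 15 min and 10 min; a lower number here means a stronger inhibitor, a higher number a weaker inhibitor. Within the data shown here, compound 1 gives 60 nM and compound 2 gives 30 nM; these two numbers lie within the usual scatter of each other, so neither compound can be set apart from the other on this assay, and no reliable step between them is available. Compound 3 `Cc1ccc(-c2csc(Nc3ccc(O)cc3)n2)cc1` has not yet been measured in this assay. It differs from compound 1 in one place: methyl in place of fluoro on an aromatic carbon. Among the measured compounds shown here, since no measured pair shows what this kind of exchange does, the expectation rests only on compound 1 and the small size of the change, and the estimated step of a 1.2-fold lower number from compound 1 to compound 3 (0.08 log units; within the scatter) is expected to stay within the scatter, in no particular direction. Compound 3 is therefore expected to give about 50 nM, with a range from 15 nM to 200 nM.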

Compound 3, half-maximal inhibitory concentration: 60 nM
Compound 3: the middle estimate sits 1.2-fold (0.08 log units) below what was measured; the range from low to high includes it.
By their numbers in this assay, from the lowest: compounds 2, 1 and 3 (each within the scatter of the next).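

Among these compounds, this is the first measured pair for this exchange: in this assay, methyl in place of fluoro on an aromatic carbon, para to a large group, gives no change at the digits printed from compound 1 to compound 3 (within the scatter). The earlier compounds shown here could not show this, as compounds 1 and 2 differ in more than one place and offered no step to read. At this position on the shared core, then, the assay does not tell fluoro from methyl, and nothing at hand explains why.

The compounds shown leave open whether a group of a different kind at this position, such as an amine, a carboxylic acid or a longer chain, would also leave the number within the scatter. They also leave open whether methyl in place of fluoro would give the same result on another aromatic carbon.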